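Halogen swap on the carboxyphenyl ether in the mGlu2 series

The compounds below may be only part of what the source reports. "The series", "measured", "known", "first", "only" and "open" are said of these compounds alone.

Three compounds sharing one core have numbers in an assay for positive allosteric modulation of metabotropic glutamate receptor 2 (Rattus norvegicus); a lower number here means that less compound is needed, a higher number that more compound is needed for the effect. Compound 1 `Cc1c(OC[C@@H](C)COc2ccc(F)c(C(=O)O)c2)ccc(C(=O)CC(C)(C)C)c1O` gives 112 nM. Compound 2 `Cc1c(OC[C@@H](C)COc2ccc(C(=O)O)cc2Cl)ccc(C(=O)CC(C)(C)C)c1O` gives 477 nM. Compound 3 `Cc1c(OC[C@@H](C)COc2ccc(C(=O)O)c(F)c2)ccc(C(=O)CC(C)(C)C)c1O` gives 261 nM. The change a 4.3-fold higher number from compound 1 to compound 2 (0.63 log units; beyond the scatter) and the change a 2.3-fold higher number from compound 1 to compound 3 (0.37 log units; beyond the scatter) both lie beyond the scatter, whereas a 1.8-fold lower number from compound 2 to compound 3 (0.26 log units; within the scatter) does not; compound 3 therefore stands apart from compound 1 but not from compound 2.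

Compound 4 `Cc1c(OC[C@@H](C)COc2ccc(C(=O)O)c(Cl)c2)ccc(C(=O)CC(C)(C)C)c1O` differs from compound 3 by chloro in place of fluoro on an aromatic carbon, on an aromatic carbon of a six-membered aromatic ring of carbon only, ortho to a carboxy group and meta to a large group. For the measured compounds named here, no measured pair shows this exact swap at a fixed position. The nearest guide is a 1.8-fold lower number from compound 2 to compound 3 (0.26 log units; within the scatter), where a chloro on the same ring family, at a different position, and a fluoro gave numbers within the scatter of each other. The expectation for compound 4 is therefore a step of a 1.1-fold higher number from compound 3 to compound 4 (0.06 log units; within the scatter), not beyond the scatter. Compound 4 is estimated at 300 nM, with a range from 150 nM to 650 nM.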

Compound 4, half-maximal effective concentration: 50 nM
Compound 4: the middle estimate sits 6.0-fold (0.78 log units) above what was measured, outside the stated range (below it).
By their numbers in this assay, from the lowest: compound 4; then compound 1; then compounds 3 and 2 (each within the scatter of the next).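

In this assay, chloro in place of fluoro, ortho to a carboxy group and meta to a large group, gives a 5.2-fold lower number from compound 3 to compound 4 (0.72 log units; beyond the scatter), so the identity of the halogen matters at this position. The placement of the chloro matters as well: 4-carboxy-3-chlorophenyl in place of 4-carboxy-2-chlorophenyl gives a 9.5-fold lower number from compound 2 to compound 4 (0.98 log units; beyond the scatter), which shows that the closeness of compound 2 and compound 3 says little about a halogen swap at a fixed position. The same group in place of 3-carboxy-4-fluorophenyl gives a 2.2-fold lower number from compound 1 to compound 4 (0.35 log units; beyond the scatter), leaving compound 4 with the lowest number of the four, its steps to all the others beyond the scatter.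

From the compounds shown here alone, whether bromo, methyl or trifluoromethyl at this position would extend the gain remains open. No measurement shown accounts for the difference between chloro and fluoro here.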